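Swapping a methoxy for a chloro on a sulfonyl aryl

This account rests on a few compounds, and the source may have more. Where it says the series, first, only, none or still open, it means among the compounds named here.

Compound 1, with the structure `COc1ccc2ncc(S(=O)(=O)c3ccc(OC)c(Cl)c3)c(N3CCC(C)CC3)c2c1`, was tested in an assay on isolated protein for displacement of a labelled ligand from metabotropic glutamate receptor 5 (Homo sapiens), with a stated time of 60 min, tested at 1 uM (a higher number here means more inhibition at the concentration tested (going by the name of the read-out), a lower number less inhibition), where compound 1 gives 21%. This is the lowest of the three numbers seen so far. Compound 2, `CC1CCN(c2c(S(=O)(=O)c3ccc(F)cc3)cnc3cc(Cl)ccc23)CC1`, gives 91% in this assay, and compound 3, `CC1CCN(c2c(S(=O)(=O)c3cccc(Cl)c3)cnc3ccc(Cl)cc23)CC1`, gives 92%. Among the compounds with values here, both stand beyond the scatter above compound 1, but each of them differs from compound 1 in more than one place, so no single step between measured compounds can be read from these three.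

Compound 4, `COc1ccc2ncc(S(=O)(=O)c3ccc(Cl)c(Cl)c3)c(N3CCC(C)CC3)c2c1`, has not yet been measured. It differs from compound 1 by one change only: chloro in place of methoxy on an aromatic carbon. Taken one bond further out, the change reads 3-chloro-4-methoxyphenyl to 3,4-dichlorophenyl, and it sits ortho to a chloro group and para to a large group.

Within the data shown here, with no measured step of this kind, the direction is uncertain, but the two higher numbers belong to compounds that carry halogen-only aryl groups on the sulfonyl, as compound 4 would. The step of a number 29 percentage points higher from compound 1 to compound 4 (beyond the scatter) is therefore expected to be a rise, beyond the scatter. Compound 4 is estimated at 50%, with a range from 20% to 80%.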

Compound 4, a percentage reported as inhibition, at one concentration (the size of the read-out at that concentration, not a potency): 87%
Beside the measured number, compound 4's estimate is 37 percentage points below it; the whole stated range lies below it.
By their numbers in this assay, from the lowest: compound 1; then compounds 4, 2 and 3 (each within the scatter of the next).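

Within the data shown here, the exchange of methoxy for chloro on this aromatic carbon, ortho to a chloro group and para to a large group, produces a number 66 percentage points higher from compound 1 to compound 4 (beyond the scatter) in this assay; it is the first comparison here in which only one place differs, so this large rise can be tied to that single change. It also shows that the methoxy on the shared core does not by itself hold the number down, since compound 4 keeps that group and still gives 87%. Nothing available here explains why this exchange has so large an effect on the read-out.

The compounds shown leave open whether the rise comes from losing the methoxy or from gaining the chloro, and a hydrogen, fluoro, methyl, ethoxy or amino group on the same carbon would help to separate the two. From the compounds shown here alone, since this read-out is taken at a single concentration and describes inhibition at that concentration, not potency, it also remains open how large the difference between compound 1 and compound 4 would be across a range of concentrations.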